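Swapping the aryl group on a triazole nitrogen

The compounds below may be only part of what the source reports. "The series", "measured", "known", "first", "only" and "open" are said of these compounds alone.

Compound 1 `CCc1ccccc1-n1nncc1CN1C(=O)C2(C(C#N)=C(N)Oc3c(N)cc4nc5ccccc5nc4c32)c2ccccc21` is one of two measured members of this small series. In a functional assay on A549 cells (Homo sapiens) for antiproliferative activity, read by MTT assay, with a stated time of 48 h (a higher number here means a weaker inhibitor, a lower number a stronger inhibitor), compound 1 gives 24600 nM. Compound 2 `CCc1cccc(C)c1-n1nncc1CN1C(=O)C2(C(C#N)=C(N)Oc3c(N)cc4nc5ccccc5nc4c32)c2ccccc21` carries a methyl in place of hydrogen on an aromatic carbon of the same ring. For compound 2 this assay reports only a limit, > 50000 nM, not a number. The step of an at least 2.0-fold higher number from compound 1 to compound 2 (0.30 log units; that floor lies within the scatter) is therefore known only as a floor, and that floor lies within the scatter; it rests on (the limit of > 50000 nM in this assay, at which 1 of the 2 values shown sits).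

Compound 3 `N#CC1=C(N)Oc2c(N)cc3nc4ccccc4nc3c2C12C(=O)N(Cc1cnnn1-c1c(F)cccc1F)c1ccccc12` is not yet measured. Relative to compound 2 the change is 2,6-difluorophenyl in place of 2-ethyl-6-methylphenyl on an aromatic nitrogen. Among the compounds with values here, no measured step exchanges one aryl group for another on this nitrogen, so the single measured step, which alters only a methyl, gives little guidance, and compound 2 itself stands only at a limit. Compound 3 is expected to give about 40000 nM, within 15000 nM to 150000 nM. This estimate means a step of an at least 1.2-fold lower number from compound 2 to compound 3 (0.09 log units; that floor lies within the scatter), expected to stay within the scatter rather than mark a real change.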

Compound 3, half-maximal inhibitory concentration: > 50000 nM
Compound 3: a limit, no number; the forecaster's own chance of this, stated with the estimate: 40%; middle value at least 1.2-fold (0.09 log units) away from the limit.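

In this assay compound 3 gives > 50000 nM, which is a limit of the assay and not a number. This shows that a limit at this aromatic nitrogen is not confined to the 2-ethyl-6-methylphenyl group: 2,6-difluorophenyl, which carries fluorine in place of the carbon chains, also gives no number, leaving compound 1 as the only one of the three with a measured value. Exchanging 2-ethylphenyl for 2,6-difluorophenyl gives an at least 2.0-fold higher number from compound 1 to compound 3 (0.30 log units; that floor lies within the scatter), so this step too is known only as a floor, and the step between compound 2 and compound 3 cannot be read because both compounds sit at the same limit: the limit of > 50000 nM in this assay, at which 2 of the 3 values shown sit.

On these data alone, the true values of compound 2 and compound 3, and so any real difference from compound 1 or between the two of them, remain open. Also open, as far as these compounds go, is how a plain phenyl group, or a phenyl group bearing a methoxy group or an amine, would behave on this nitrogen in this assay.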